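The source may hold more compounds than are shown below. What is called first, only, known or untested is meant among the compounds shown, and "the series" means these compounds.

Measured compounds:
Compound 1 `COc1cc(-c2nn(-c3cccc(NC(=O)Nc4cc(C(F)(F)F)cc(C(F)(F)F)c4)c3)cc2-c2ccncc2)ccc1Cl`: 694 nM
Compound 2 `COc1cc(-c2nn(-c3cccc(NC(=O)c4cccc(C(F)(F)F)c4)c3)cc2-c2ccncc2)ccc1Cl`: 978 nM
Compound 3 `O=C(Nc1cccc(-n2cc(-c3ccncc3)c(-c3ccc(Cl)c(O)c3)n2)c1)Nc1cc(C(F)(F)F)cc(C(F)(F)F)c1`: 600 nM

In a functional assay on SK-MEL-5 cells (Homo sapiens) for inhibition, read by sulforhodamine B assay, with a stated time of 48 h (a higher number here means a weaker inhibitor of growth, a lower number a stronger inhibitor of growth), compound 2 gives the highest of the three numbers, yet its gaps to compound 1 and to compound 3 both lie within the scatter. Compound 4 `COc1cc(-c2nn(-c3cccc(NC(=O)Nc4ccc(Cl)c(C(F)(F)F)c4)c3)cc2-c2ccncc2)ccc1Cl` is not yet measured; it differs from compound 2 by (4-chloro-3-(trifluoromethyl)phenyl)amino in place of 3-(trifluoromethyl)phenyl on a carbonyl carbon. For the measured compounds named here, the only single-point step measured, a 1.2-fold lower number from compound 1 to compound 3 (0.06 log units; within the scatter), concerns a different part of the core and does not touch this change. Compound 1, which shares the urea link, and compound 2 show values within the scatter of each other. The expectation for compound 4 is therefore a number close to compound 1, with a 1.5-fold lower number from compound 2 to compound 4 (0.18 log units; within the scatter) expected. Compound 4 is estimated at 650 nM, in the range 300 nM to 1400 nM.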

Compound 4, concentration for 50% growth inhibition: 818 nM
The estimate for compound 4 lay 1.3-fold (0.10 log units) below the measured number; measured number inside the range.
By their numbers in this assay, from the lowest: compounds 3, 1, 4 and 2 (each within the scatter of the next).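

In this assay, putting (4-chloro-3-(trifluoromethyl)phenyl)amino in place of 3-(trifluoromethyl)phenyl on the carbonyl carbon gives a 1.2-fold lower number from compound 2 to compound 4 (0.08 log units; within the scatter). This place therefore accepts the larger group, with its added nitrogen, chlorine and hydrogen-bond donor, with no change beyond the scatter. No measurement here offers an explanation for this result.

The nitrogen and chlorine arrive together, so the compounds shown cannot separate their contributions. Also open, as far as these compounds go, is how a saturated amine such as morpholine would read on this carbonyl carbon.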